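This account rests on a few compounds, and the source may have more. Where it says the series, first, only, none or still open, it means among the compounds named here.

Measured in a functional assay on DU-145 cells (Homo sapiens) for inhibition, read by trypan blue exclusion, with a stated time of 72 h; a lower number here means a stronger inhibitor, a higher number a weaker inhibitor:
compound 1 `Cn1c(=O)c(S(=O)(=O)c2ccc(F)cc2)cc2cnc(Nc3ccc4[nH]ccc4c3)nc21`: 300 nM
compound 2 `COc1ccc(S(=O)(=O)c2cc3cnc(Nc4cccc5[nH]ccc45)nc3n(C)c2=O)cc1`: 5000 nM
compound 3 `Cn1c(=O)c(S(=O)(=O)c2ccc(F)cc2)cc2cnc(Nc3ccc4[nH]ncc4c3)nc21`: 5000 nM

Compound 3, at 5000 nM, is level with compound 2, and the two share the highest number of the three. Compound 1 stands well apart from both.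

Next is compound 4 `Cn1c(=O)c(S(=O)(=O)c2ccc(F)cc2)cc2cnc(Nc3cccc4[nH]ccc34)nc21`, with 1H-indol-4-yl in place of 1H-indazol-5-yl on a nitrogen on an aromatic ring.

Among the compounds with values here, the only measured step at this place is a 17-fold higher number from compound 1 to compound 3 (1.22 log units; beyond the scatter). It is large and shows that this assay responds to a change here, but it involves 1H-indol-5-yl, not the incoming group. Compound 2 carries the same 1H-indol-4-yl and gives 5000 nM, although it is not a one-place neighbour of compound 4. That value argues against expecting the full recovery seen with compound 1, so only a small move towards a lower number is expected. The expected change is a 1.7-fold lower number from compound 3 to compound 4 (0.22 log units; within the scatter), which would not clearly exceed the scatter. For compound 4 the estimated value is 3000 nM, with an expected range of 800 nM to 8000 nM.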

Compound 4, half-maximal inhibitory concentration: 750 nM
The estimate for compound 4 lay 4.0-fold (0.60 log units) above the measured number; the measured number lies below the stated range.
By their numbers in this assay, from the lowest: compound 1; then compound 4; then compounds 2 and 3 (each within the scatter of the next).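

In this assay the attachment point of the indole matters: a 2.5-fold higher number from compound 1 to compound 4 (0.40 log units; beyond the scatter) is beyond the scatter, so 1H-indol-4-yl is not equivalent to 1H-indol-5-yl on this nitrogen. Even so, a 6.7-fold lower number from compound 3 to compound 4 (0.82 log units; beyond the scatter) shows that 1H-indol-4-yl gives a lower number here than 1H-indazol-5-yl. With 1H-indol-4-yl held constant, a 6.7-fold lower number from compound 2 to compound 4 (0.82 log units; beyond the scatter) with fluoro in place of methoxy on an aromatic carbon, so the high number of compound 2 cannot be assigned to 1H-indol-4-yl alone. No supporting data bear on the reason for these differences.

As far as these compounds go, whether methoxy raises the number to the same extent alongside 1H-indol-5-yl remains open. So does the effect of an amine or a carboxylic acid in place of fluoro on this series.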